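Nitro in Place of Cyano Across Two Cores

A few compounds are considered here, and "the series" means these few. Any claim that something is new, unique, unknown or untested is made for them only; others in the source may bear on it.

Compound 1 `CC(O)(CSc1ccc(S(F)(F)(F)(F)F)cc1)C(=O)Nc1ccc(C#N)c(C(F)(F)F)c1` and compound 2 `CC(O)(CSc1ccc(S(F)(F)(F)(F)F)cc1)C(=O)Nc1ccc([N+](=O)[O-])c(C(F)(F)F)c1` share one core, while compound 3 `CC(O)(COc1ccc(S(F)(F)(F)(F)F)cc1)C(=O)Nc1ccc(C#N)c(C(F)(F)F)c1` and compound 4 `CC(O)(COc1ccc(S(F)(F)(F)(F)F)cc1)C(=O)Nc1ccc([N+](=O)[O-])c(C(F)(F)F)c1` share another; the difference between the two cores is not broken down here. In a functional assay on VCaP cells (Homo sapiens) for antiproliferative activity, read by propidium iodide staining, with a stated time of 96 h (a higher number here means a weaker inhibitor, a lower number a stronger inhibitor), compound 1 gives 30200 nM, and compound 2 gives 10100 nM. The change between them, (nitro in place of cyano on an aromatic carbon), produced a 3.0-fold lower number from compound 1 to compound 2 (0.48 log units; beyond the scatter). In this assay compound 3 gives 30100 nM, a value within the scatter of that of compound 1. Compound 4 carries the same change on the second core, (nitro in place of cyano on an aromatic carbon). Because the same change earlier gave a 3.0-fold lower number from compound 1 to compound 2 (0.48 log units; beyond the scatter), the expected step is a 3.0-fold lower number from compound 3 to compound 4 (0.48 log units; beyond the scatter). Compound 4 is therefore estimated at 10000 nM, with a likely range from 4000 nM to 25000 nM. This expectation rests on a single earlier instance and remains uncertain.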

Compound 4, half-maximal inhibitory concentration: 100000 nM
Estimate against measurement, compound 4: 10-fold (1.00 log units) below, and the stated range ends below it.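

In this assay, nitro in place of cyano on an aromatic carbon gave a 3.3-fold higher number from compound 3 to compound 4 (0.52 log units; beyond the scatter) and so did not repeat on the second core what it had done on the first. The result shows that, for these two pairs, neither the size nor the direction of the change carries over from one core to the other, although it does not show which part of the difference between the cores is responsible. Two pairs also set no rule for any further core, and the comparison of the two steps reads: the same change on two cores in this assay, a 3.0-fold lower number (0.48 log units; beyond the scatter) from compound 1 to compound 2 and a 3.3-fold higher number (0.52 log units; beyond the scatter) from compound 3 to compound 4, 9.9-fold (1.00 log units) apart, beyond the scatter of two such steps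

Going by these compounds, whether an amine or a carboxylic acid on the same aromatic carbon would also separate the two cores remains open. So does whether a longer chain on the core would alter the outcome of the change.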